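Moving the chlorine from compound 2 to compound 3

The compounds below may be only part of what the source reports. "The series", "measured", "known", "first", "only" and "open" are said of these compounds alone.

Going by the values given here, in a functional assay on SGC-7901 cells (Homo sapiens) for antiproliferative activity, read by MTT assay, with a stated time of 24 h (a lower number here means a stronger inhibitor, a higher number a weaker inhibitor), compound 2 `O=C(NNC(=O)c1ccccc1NS(=O)(=O)c1cnc(O)nc1O)c1ccccc1Cl` gives 2410 nM as the only true number so far. Compound 1 `Cc1cccc(NNC(=O)c2ccccc2NS(=O)(=O)c2cnc(O)nc2O)c1` reads > 20000 nM and that is a limit of the assay, not a number. Among the compounds with values here, compound 3 `O=C(NNC(=O)c1ccccc1NS(=O)(=O)c1cnc(O)nc1O)c1cccc(Cl)c1` has the same atoms as compound 2 but joined differently, with 3-chlorophenyl in place of 2-chlorophenyl on a carbonyl carbon as the single change. Within the data shown here, only one measured step is available. Because an at least 8.2-fold lower number from compound 1 to compound 2 (0.91 log units; beyond the scatter) came from exchanging a whole group, (2-chlorophenyl)carbonyl in place of 3-methylphenyl on an amine nitrogen, it says little about moving a chlorine. No step beyond the scatter is therefore expected in this assay for compound 3. The estimated change is a 1.2-fold higher number from compound 2 to compound 3 (0.10 log units; within the scatter) with no firm direction. The estimate for compound 3 is 3000 nM with 1000 nM to 9000 nM as the expected range.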

Compound 3, half-maximal inhibitory concentration: 1820 nM
The estimate for compound 3 lay 1.6-fold (0.22 log units) above the measured number; measured number inside the range.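

In this assay, shifting the chlorine from 2-chlorophenyl to 3-chlorophenyl on the carbonyl carbon gives a 1.3-fold lower number from compound 2 to compound 3 (0.12 log units; within the scatter), so this assay cannot tell the two chlorine placements apart. The large gain over compound 1 also survives the shift, as the exchange of a whole group, now with the chlorine in its new place, gives an at least 10-fold lower number from compound 1 to compound 3 (1.04 log units; beyond the scatter). The reading for compound 1 is a limit and not a number, so the full size of this step stays unknown: the limit of > 20000 nM in this assay, at which 1 of the 3 values shown sits.

The compounds shown leave open whether a methoxy group or a nitrile in place of the chlorine would move the number beyond the scatter. They also cannot separate the contribution of the carbonyl from that of the chlorine, a question that 3-methylphenyl on a carbonyl carbon could address.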